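This account rests on a few compounds, and the source may have more. Where it says the series, first, only, none or still open, it means among the compounds named here.

Compound 1 `Cc1cc(NC(=O)Nc2ccc(Cl)c(Cl)c2)c2ccccc2n1`: > 25000 nM
Compound 2 `Cc1ccc(NC(=O)Nc2cc(C)nc3ccccc23)cc1`: > 25000 nM
Compound 3 `Cc1cc(NC(=O)Nc2ccc(F)c(F)c2)c2ccccc2n1`: > 25000 nM

All three compounds were tested in an ADME assay on HEK293 cells (Homo sapiens) for cytotoxicity, with a stated time of 72 h (a lower number here means that less compound is needed, a higher number that more compound is needed for the effect), and each entry is a limit of the assay, not a number. Compound 3 gives > 25000 nM, which is such a limit. The three compounds share the same ceiling: the limit of > 25000 nM in this assay, at which 3 of the 3 values shown sit. Compound 3 therefore has no exact place among them, and no order can be drawn.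

Compound 4 `COc1ccc(NC(=O)Nc2cc(C)nc3ccccc23)cc1F` is compound 3 with methoxy in place of fluoro on an aromatic carbon, ortho to a fluoro group and para to a large group: methoxy in place of fluoro on an aromatic carbon. For the measured compounds named here, no measured pair here differs in one place, so the data give no direct guide to the size of such a step. With all three values sitting at the limit, the expectation is no change beyond the scatter, in either direction. The expected step is a number no higher from compound 3 to compound 4 (the limit leaves the size open). Compound 4 is expected at 25000 nM, with an estimated range from 12000 nM to 25000 nM.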

Compound 4, half-maximal effective concentration: > 25000 nM
Compound 4 ended at the assay's limit (the forecaster's own chance of this, stated with the estimate: 85%); the middle value sits exactly at the limit.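

In this assay no step can be read from compound 3 to compound 4, because both values are limits and not numbers: the limit of > 25000 nM in this assay, at which 4 of the 4 values shown sit. The compounds shown leave open how much of any of them is needed for the effect, and whether methoxy in place of fluoro changes that amount.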